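A straight pentyl chain in place of tert-butyl

This account rests on a few compounds, and the source may have more. Where it says the series, first, only, none or still open, it means among the compounds named here.

Compound 2 `CC(C)(C)c1cc(=O)c2ccc(O)cc2o1` carries a tert-butyl group on the shared core, and in an assay on isolated protein for inhibition of Polyunsaturated fatty acid lipoxygenase ALOX15 (Homo sapiens) (a higher number here means a weaker inhibitor, a lower number a stronger inhibitor), compound 2 gives > 100000 nM, which is a limit of the assay rather than a measured number. Its close relative compound 1 `CC(C)c1cc(=O)c2ccc(O)cc2o1` carries an isopropyl group in the same place; in this assay compound 1 gives > 100000 nM, again a limit. Within the data shown here, the one measured step, a step that the two limits leave unreadable from compound 1 to compound 2, cannot be sized because both ends rest on (the limit of > 100000 nM in this assay, at which 2 of the 2 values shown sit). Compound 3 `CCCCCc1cc(=O)c2ccc(O)cc2o1` is the next compound to be tested. It differs from compound 2 by pentyl in place of tert-butyl on an aromatic carbon. Among the measured compounds shown here, no measured step speaks to exchanging a branched group for a straight chain on the shared core, and the single measured step gives no readable size. The expectation for compound 3 in this assay is that it also falls around the same limit, estimated at 100000 nM with a range from 20000 nM to 500000 nM. The expected step of a number no higher from compound 2 to compound 3 (the limit leaves the size open) is thus none beyond the scatter, though only a measurement can settle this.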

Compound 3, half-maximal inhibitory concentration: > 100000 nM
Compound 3: only a limit was reported (the forecaster's own chance of this, stated with the estimate: 70%); the middle value sits exactly at the limit.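

Among these compounds, compound 3 sits at a limit of the assay, as do compound 1 and compound 2, so neither the step to compound 3 from compound 2 nor the one from compound 1 can be read: the limit of > 100000 nM in this assay, at which 3 of the 3 values shown sit.

Going by these compounds, how isopropyl, tert-butyl and pentyl on the shared core compare in this assay stays open.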